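The source may report more compounds than this note shows. Statements on the series, on what has been measured and on what is new or still open speak of the compounds shown alone.

Compound 1 `C[Se]c1nc([Se]C)c2cccnc2n1` has in a functional assay on HTB-54 cells (Homo sapiens) for cytotoxicity, read by MTT assay, with a stated time of 72 h (a lower number here means a stronger inhibitor of growth, a higher number a weaker inhibitor of growth), the result "not determined" (no result reported); the measurement was not determined, so there is no number on which compound 1 can be placed. Among the measured compounds shown here, the only measured member of the series is compound 2 `CCCCC[Se]c1nc(NCc2ccccc2)c2ccccc2n1`, which in this assay gives 81100 nM, a weak result. For the measured compounds named here, no step between two measured compounds exists, so nothing can be read here about the effect of any single change. Compound 3 `C[Se]c1nc(N)c2cccnc2n1` differs from compound 1 by one nitrogen atom in place of a group of 2 heavy atoms (1 carbon, 1 selenium; no ring), on an aromatic carbon. With compound 1 unmeasured, neither the size nor the direction of the step from compound 1 to compound 3 in this assay can be taken from data; no movement beyond the usual scatter is assumed either way. Resting only on compound 2 with 81100 nM as the one reference point of the series, compound 3 is expected to give about 90000 nM in this assay, with a range from 30000 nM to 250000 nM.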

Compound 3, concentration for total growth inhibition: > 100000 nM
Compound 3: no number, only a limit; the forecaster's own chance of this, stated with the estimate: 25%; at least 1.1-fold (0.04 log units) between middle value and limit.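

In this assay compound 3 gives > 100000 nM, which is a limit and not a number, and compound 1 has no number, so no new step can be read between them. The compounds shown leave open whether amino on that aromatic carbon shifts growth inhibition in either direction.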